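Phenyl in place of 5-hydroxypentyl on the ring nitrogen

A few compounds are considered here, and "the series" means these few. Any claim that something is new, unique, unknown or untested is made for them only; others in the source may bear on it.

Compound 1 `CSc1nc(NCCCc2ccccc2)c2ccccc2n1` — in a functional assay on CCRF-CEM cells (Homo sapiens) for cytotoxicity, read by MTT assay, with a stated time of 72 h (on this read-out higher numbers stand for lower toxicity in this test and lower numbers for higher toxicity in this test), compound 1 gives > 100000 nM, a limit of the assay.
Compound 2 `CSc1nc(NCCCCCO)c2ccccc2n1` — in this assay compound 2 gives > 100000 nM, likewise a limit.

Compound 2 thus stands at the limit of > 100000 nM in this assay, at which 2 of the 2 values shown sit. Within the data shown here, the only measured step, a step that the two limits leave unreadable from compound 1 to compound 2, gives no readable size. Compound 3 `CSc1nc(Nc2ccccc2)c2ccccc2n1` differs from compound 2 by phenyl in place of 5-hydroxypentyl on a nitrogen on an aromatic ring. Among the measured compounds shown here, no measured step bears on this change, and both known values sit at the limit, so no step beyond the scatter is expected in this assay. Compound 3 is therefore estimated at 150000 nM, within 40000 nM to 600000 nM. That estimate corresponds to an expected step that the limit leaves unreadable from compound 2 to compound 3.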

Compound 3, concentration lethal to 50% of the cells: > 100000 nM
Compound 3 ended at the assay's limit (the forecaster's own chance of this, stated with the estimate: 75%); the middle value is on the limit's open side.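

Between compound 2 and compound 3 no step can be read in this assay, as both values are limits. Whether phenyl and 5-hydroxypentyl differ at all in toxicity in this test stays open, as every value shown sits at the same limit: the limit of > 100000 nM in this assay, at which 3 of the 3 values shown sit.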